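Methoxy for methyl on the bromoacrylamide core

A few compounds are considered here, and "the series" means these few. Any claim that something is new, unique, unknown or untested is made for them only; others in the source may bear on it.

Compound 1 `C=C(Br)C(=O)Nc1cccc(-c2cn3nc(-c4ccc(C)cc4)sc3n2)c1` gives 2000 nM in a functional assay on HeLa cells (Homo sapiens) for inhibition, read by cell counting, with a stated time of 4 days; on this read-out higher numbers stand for weaker inhibition and lower numbers for stronger inhibition. Among the three compounds measured, it stands second highest: compound 2 `C=C(Br)C(=O)Nc1cccc(-c2cn3c(-c4ccc(OC)cc4)csc3n2)c1` gives 860 nM, and compound 3 `COc1ccc(-c2csc3nc(-c4cccc(N)c4)cn23)cc1` gives 19000 nM. Among the measured compounds shown here, the only single-point step recorded runs a 22-fold higher number from compound 2 to compound 3 (1.34 log units; beyond the scatter), a change at the anilide nitrogen rather than at the aryl ring, so it says nothing direct about the present question. Compound 4 `C=C(Br)C(=O)Nc1cccc(-c2cn3nc(-c4ccc(OC)cc4)sc3n2)c1` differs from compound 1 by methoxy in place of methyl on an aromatic carbon. For the measured compounds named here, no measured pair isolates this change: compound 2 carries a methoxy group but also a different core, so its number can be compared with that of compound 1 only loosely, and the two differ in two places at once. On that thin basis, a step of at most modest size is expected, if anything toward a lower number, and the expected step is a 1.3-fold lower number from compound 1 to compound 4 (0.12 log units; within the scatter). Compound 4 is therefore expected to give 1500 nM, within a range of 600 nM to 4000 nM.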

Compound 4, half-maximal inhibitory concentration: 2300 nM
Estimate against measurement, compound 4: 1.5-fold (0.19 log units) below; the measured number falls inside the stated range.
By their numbers in this assay, from the lowest: compound 2; then compounds 1 and 4 (each within the scatter of the next); then compound 3.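

With the core held constant, methoxy in place of methyl on the aromatic carbon para to a large group gives a 1.2-fold higher number from compound 1 to compound 4 (0.06 log units; within the scatter) in this assay and thus leaves the two compounds indistinguishable on this read-out. Among the compounds shown here, this is the first direct reading of the change, as compound 2 carries its methoxy group on a different core and could not isolate it. No measurement at hand offers an explanation for this result.

From the compounds shown here alone, whether this position tolerates groups of a different kind, such as an amine, a carboxylic acid or a longer alkoxy chain, remains open. So does whether 4-methylphenyl to 4-methoxyphenyl would read the same way on the core of compound 2, as this single pair covers only the core of compound 1.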